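Closing the amine into a ring on the benzamide

The source may hold more compounds than are shown below. What is called first, only, known or untested is meant among the compounds shown, and "the series" means these compounds.

Compound 1 `CN(C)CCCN(Cc1ccccc1)c1cccc(C(=O)N2CCc3ccc(OS(N)(=O)=O)cc3C2)c1`: 23.8%
Compound 2 `CCN(Cc1ccccc1)c1ccc(C(=O)N2CCc3ccc(OS(N)(=O)=O)cc3C2)cc1`: 66.9%
Compound 3 `CCN(Cc1cccc(Br)c1)c1cccc(C(=O)N2CCc3ccc(OS(N)(=O)=O)cc3C2)c1`: 20.9%

Three sulfamates sharing one core have been measured in an assay on HEK293 cells for inhibition of Steryl-sulfatase (Homo sapiens), tested at 0.1 uM; a higher number here means a stronger effect of the compound at the concentration tested, a lower number a weaker effect. Compound 3 stands lowest of the three in this assay, giving 20.9%. Its nearest neighbour on the numbers is compound 1, whose 23.8% lies within the scatter of it, so the two cannot be ordered. Compound 2, at 66.9%, sits well beyond the scatter above compound 3.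

The next compound, compound 4 `NS(=O)(=O)Oc1ccc2c(c1)CN(C(=O)c1cccc(N3CCc4ccccc4C3)c1)CC2`, is derived from compound 3 by a single change:

1,2,3,4-tetrahydroisoquinolin-2-yl in place of (3-bromobenzyl)(ethyl)amino on an aromatic carbon

Among the measured compounds shown here, the change is made on an aromatic carbon, meta to a large group, and no pair of measured compounds shows this exact step, so its size has to be estimated. Compound 1 and compound 3, which share the same attachment pattern, both sit low, while the higher number of compound 2 belongs to a different pattern and so gives no direct guide here.

Compound 4 is therefore expected to remain near the low end, with an estimated 30% (range 10% to 60%), which would mean an expected step of a number 9.1 percentage points higher from compound 3 to compound 4 (within the scatter) that may well stay within the scatter.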

Compound 4, a percentage reported as inhibition, at one concentration (the size of the read-out at that concentration, not a potency): 24.1%
Compound 4: the middle estimate sits 5.9 percentage points above what was measured; the measured number falls inside the stated range.
By their numbers in this assay, from the lowest: compounds 3, 1 and 4 (each within the scatter of the next); then compound 2.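

In this assay, putting 1,2,3,4-tetrahydroisoquinolin-2-yl in place of (3-bromobenzyl)(ethyl)amino on this aromatic carbon gives a number 3.2 percentage points higher from compound 3 to compound 4 (within the scatter), so the two compounds cannot be ordered. Among the compounds shown here, this is the first reading of a ring-closed amine at this place, and it shows that tying the nitrogen substituents into a six-membered non-aromatic ring leaves the read-out indistinguishable from that of the open amine, even though the bromine is lost in the same step. For the compounds shown here, the single step joins those two alterations, so neither can be read alone, and nothing at hand offers an explanation for the outcome.

The compounds shown leave open whether a smaller or more heteroatom-rich cyclic amine, such as pyrrolidin-1-yl or morpholin-4-yl, would read differently on this aromatic carbon. They also leave open whether a bromine on the aromatic ring of the 1,2,3,4-tetrahydroisoquinolin-2-yl group would give a number beyond the scatter of that of compound 4.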